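The compounds below may be only part of what the source reports. "The series", "measured", "known", "first", "only" and "open" are said of these compounds alone.

Of the compounds shown here, two have been tested in an assay on HEK293 cells for displacement of a labelled ligand from sodium-dependent dopamine transporter (Homo sapiens); a lower number here means a stronger inhibitor, a higher number a weaker inhibitor. Compound 1, with the structure `Cc1cc(N)c(Sc2ccccc2CN(C)C)cc1F`, returned only a limit of the assay, > 10000 nM. Compound 2, with the structure `CN(C)Cc1ccccc1Sc1ccc(CF)cc1N`, likewise returned only a limit, > 10000 nM. Both measurements sit at the limit of > 10000 nM in this assay, at which 2 of the 2 values shown sit, so compound 2 stands at the edge of what the assay can report, with no number that would rank it against compound 1. Among the compounds with values here, no step between the measured compounds can be read from two limits.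

Compound 3, with the structure `CN(C)Cc1ccccc1Sc1ccc(CCF)cc1N`, differs from compound 2 by one change: fluoromethyl in place of fluoro on a saturated chain carbon bound to an aromatic carbon. Within the data shown here, with both measured values at the limit, there is no measured step to build on. Such a modest lengthening of the fluorinated chain is expected to matter little, so the step that the limit leaves unreadable from compound 2 to compound 3 is expected to be none beyond the scatter, with a good chance that compound 3 again returns only a limit. Compound 3 is therefore estimated at 15000 nM, within a range from 3000 nM to 60000 nM.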

Compound 3, inhibition constant: > 10000 nM
Compound 3 ended at the assay's limit; the forecaster's own chance of this, stated with the estimate: 75%; the middle value is on the limit's open side.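

Compound 3 gives only a limit, > 10000 nM. With compound 2 also at a limit, no step can be read between compound 2 and compound 3, and all the compounds share one position: the limit of > 10000 nM in this assay, at which 3 of the 3 values shown sit.

The compounds shown leave open whether any change to the shared core gives a true number, and whether the fluorinated chain matters at all.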